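Efficacy notes: amide-to-benzyl change in the shared core

A few compounds are considered here, and "the series" means these few. Any claim that something is new, unique, unknown or untested is made for them only; others in the source may bear on it.

Three compounds on the shared core have been characterised for maximal response. In a functional assay on HEK293 cells for agonist activity at Bile acid receptor (Homo sapiens), read by a luciferase reporter (on this read-out higher numbers stand for larger maximal responses and lower numbers for smaller maximal responses), compound 1 `Cc1nc(OCc2c(-c3c(Cl)cccc3Cl)noc2C(C)C)ccc1N(C)C(=O)c1ccc(C(=O)O)cc1` gives 49%, compound 2 `CC(C)c1onc(-c2c(Cl)cccc2Cl)c1COc1ccc(N(C)C(=O)c2cccc(C(=O)O)c2)c(C(F)(F)F)n1` gives 55%, and compound 3 `Cc1cc(OCc2c(-c3c(Cl)cccc3Cl)noc2C(C)C)ncc1[N+](=O)[O-]` gives 76%. Compound 2 sits within the scatter of compound 1, so no order between those two can be read, while compound 3 stands beyond the scatter and its number is the higher of the pair.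

Compound 4 `CC(C)c1onc(-c2c(Cl)cccc2Cl)c1COc1ccc(N(C)Cc2ccc(OCCO)cc2)c(C(F)(F)F)n1` has not yet been measured in this assay. It differs from compound 2 in one place: 4-(2-hydroxyethoxy)benzyl in place of (3-carboxyphenyl)carbonyl on a nitrogen on an aromatic ring. Within the data shown here, no single-point step between measured compounds is available, so the size of the change has to be judged from the three values alone. Compound 3, which carries no carbonyl on its core, returns the highest number of the set, whereas compound 1 and compound 2, both with a (3-carboxyphenyl)carbonyl or related acid-bearing amide, give the lower two. On that thin basis a moderate increase, of a size somewhat beyond the scatter, is expected for the step of a number 10 percentage points higher from compound 2 to compound 4 (within the scatter). The estimate for compound 4 in this assay is 65%, with a range from 35% to 95%, the width reflecting that no directly comparable change has been measured.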

Compound 4, largest response reached (reported as efficacy), in percent of the reference or control that the assay uses: 59%
Estimate against measurement, compound 4: 6 percentage points above, within the range that was stated.
By their numbers in this assay, from the lowest: compounds 1, 2 and 4 (each within the scatter of the next); then compound 3.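

In this assay, among these compounds, the exchange of (3-carboxyphenyl)carbonyl for 4-(2-hydroxyethoxy)benzyl on a nitrogen on an aromatic ring gives the first single-place step, a number 4 percentage points higher from compound 2 to compound 4 (within the scatter), so at this position the maximal response can be read directly and shows no change beyond the scatter. The carbonyl and the carboxylic acid of the leaving group are therefore not required to hold the response at this level in compound 4, and a benzyl group carrying a hydroxyl-ended ether chain serves in their place, with the counted donors, acceptors and heavy atoms of the two groups unchanged. No measurement at hand bears on why the two groups read alike.

A single step at one position leaves open whether any group placed on this nitrogen can move the maximal response beyond the scatter, and whether the result holds on the other cores in the series. A benzyl group carrying an amine or a longer ether chain would test how far this position tolerates change, and the step says nothing about potency.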